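Thioether in place of ether at the aromatic carbon

A few compounds are considered here, and "the series" means these few. Any claim that something is new, unique, unknown or untested is made for them only; others in the source may bear on it.

Compound 3 `CC(C(=O)NCc1ccc(C(F)(F)F)cc1OC1CCCCC1)c1ccc(NS(C)(=O)=O)c(F)c1` gives 0.7 nM in an assay on CHO cells for antagonist activity at transient receptor potential cation channel subfamily V member 1 (Homo sapiens), read by FLIPR; on this read-out higher numbers stand for weaker inhibition and lower numbers for stronger inhibition; it sits second highest of the three numbers, with compound 1 `CC(C)COc1cc(C(F)(F)F)ccc1CNC(=O)C(C)c1ccc(NS(C)(=O)=O)c(F)c1` nearest at 0.8 nM and compound 2 `CC(C(=O)NCc1ccc(C(F)(F)F)cc1OC1CCCC1)c1ccc(NS(C)(=O)=O)c(F)c1` at 0.6 nM, and the steps among them, a 1.1-fold lower number from compound 1 to compound 3 (0.06 log units; within the scatter) and a 1.2-fold higher number from compound 2 to compound 3 (0.07 log units; within the scatter), stay within the scatter. Compound 4 `CC(C(=O)NCc1ccc(C(F)(F)F)cc1SC1CCCC1)c1ccc(NS(C)(=O)=O)c(F)c1` carries cyclopentylsulfanyl in place of cyclohexyloxy on an aromatic carbon. The ring-size part of this change is covered by a 1.2-fold higher number from compound 2 to compound 3 (0.07 log units; within the scatter), which was within the scatter; the swap of oxygen for sulfur has no measured counterpart among these compounds. A step of a 1.4-fold higher number from compound 3 to compound 4 (0.15 log units; within the scatter) is therefore expected, within the scatter or only slightly weaker. Compound 4 is estimated at 1 nM in this assay, with a range of 0.4 nM to 2.5 nM.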

Compound 4, inhibition constant: 0.3 nM
Compound 4: the middle estimate sits 3.3-fold (0.52 log units) above what was measured; the whole stated range lies above it.
By their numbers in this assay, from the lowest: compounds 4, 2, 3 and 1 (each within the scatter of the next, the first and the last beyond it).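

Among the compounds shown here, the thioether holds up at this position in this assay: the one step that swaps only oxygen for sulfur, a 2.0-fold lower number from compound 2 to compound 4 (0.30 log units; within the scatter), stays within the scatter. Against the other two ethers, cyclopentylsulfanyl passes the scatter modestly, with a 2.3-fold lower number from compound 3 to compound 4 (0.37 log units; beyond the scatter) and a 2.7-fold lower number from compound 1 to compound 4 (0.43 log units; beyond the scatter), but each of these steps also changes the carbon group on the heteroatom. Nothing available accounts for these steps.

Still open, from the compounds shown here alone, is whether sulfur behaves the same with an isobutyl or cyclohexyl group on it. Going by these compounds, how a sulfone or an amine would read at this aromatic carbon is also open.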